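Series notes: from compound 2 toward compound 4

The source may hold more compounds than are shown below. What is called first, only, known or untested is meant among the compounds shown, and "the series" means these compounds.

Compound 2 `Cc1ccc(S(=O)(=O)/C(=C/c2c(O)cc(O)cc2O)C(=O)c2ccc(Br)cc2)cc1` has been tested in a functional assay on DU-145 cells (Homo sapiens) for inhibition, read by trypan blue exclusion, with a stated time of 96 h; on this read-out higher numbers stand for weaker inhibition of growth and lower numbers for stronger inhibition of growth. In this assay compound 2 gives > 100000 nM, which is a limit of the assay and not a number. Compound 1 `O=C(/C(=C\c1c(O)cc(O)cc1O)S(=O)(=O)c1ccccc1Br)c1ccc(Br)cc1` gives 50000 nM in this assay. Compound 3 `O=C(/C(=C\c1c(O)cc(O)cc1O)Sc1ccccc1Br)c1ccc(Br)cc1` gives > 100000 nM in this assay, again a limit. The measured steps all concern the sulfur-bound part of the shared core: an at least 2.0-fold higher number from compound 1 to compound 2 (0.30 log units; that floor lies within the scatter); an at least 2.0-fold higher number from compound 1 to compound 3 (0.30 log units; that floor lies within the scatter); and a step that the two limits leave unreadable from compound 2 to compound 3. Compound 2 thus sits at the limit of > 100000 nM in this assay, at which 2 of the 3 values shown sit, and no numbered value is known for it.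

Compound 4 `Cc1ccc(S(=O)(=O)/C(=C/c2c[nH]c3ccccc23)C(=O)c2ccc(Br)cc2)cc1` is not yet measured in this assay. It differs from compound 2 in one place: 1H-indol-3-yl in place of 2,4,6-trihydroxyphenyl on a double-bonded chain carbon bound to a double-bonded chain carbon. Going by the values given here, none of the measured steps touches that part of the core, so they give no size for this change; they show only that compound 2 starts from a limit. The expected step is therefore a number no higher from compound 2 to compound 4 (the limit leaves the size open), with no direction that the shown steps support beyond the scatter. Compound 4 is estimated at 100000 nM, with a range from 15000 nM to 300000 nM, and a fair chance that only a limit is reported again.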

Compound 4, concentration for 50% growth inhibition: 10000 nM
Compound 4: middle estimate off by 10-fold (1.00 log units), on the high side, and the stated range ends above it.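

Working from this assay, the replacement of 2,4,6-trihydroxyphenyl by 1H-indol-3-yl on a double-bonded chain carbon bound to a double-bonded chain carbon gives an at least 10-fold lower number from compound 2 to compound 4 (1.00 log units; beyond the scatter), the only step in the series so far printed as beyond the scatter. Going by these compounds alone, the earlier readable steps all concerned the sulfur-bound part of the shared core and reached only floors within the scatter, so this is the first evidence that the group at this place can shift growth inhibition measurably, here with the (4-methylphenyl)sulfonyl part held constant. The true size of the step stays unknown because compound 2 is recorded only as a limit: the limit of > 100000 nM in this assay, at which 2 of the 4 values shown sit.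

The compounds shown leave open whether 1H-indol-3-yl would give a step of this kind on the shared core when it carries (2-bromophenyl)sulfonyl or (2-bromophenyl)sulfanyl instead of (4-methylphenyl)sulfonyl. They also leave open how a plain phenyl at this place, or a 1H-indol-3-yl carrying an amine or a carboxylic acid, would read out in this assay.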